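The source may report more compounds than this note shows. Statements on the series, on what has been measured and on what is new or still open speak of the compounds shown alone.

Measured so far: compound 1 `N#CC1=C(N)N(c2ccc(S(N)(=O)=O)cc2)C2=C(C(=O)CCC2)C1c1ccc(Cl)cc1Cl` with 95%, and compound 2 `CCCCNC(=S)NC1=C(C#N)C(c2ccc(Cl)cc2Cl)C2=C(CCCC2=O)N1c1ccc(S(N)(=O)=O)cc1` with 40%.

In a functional assay on Ehrlich cells (Mus musculus) for cytotoxicity, read by trypan blue exclusion, with a stated time of 2 h, tested at 100 ug/mL (a higher number here means a stronger effect of the compound at the concentration tested, a lower number a weaker effect), compound 1 gives 95%, while compound 2 gives 40%, the lower of the two numbers. Compound 3 `C=CCNC(=S)NC1=C(C#N)C(c2ccc(Cl)cc2Cl)C2=C(CCCC2=O)N1c1ccc(S(N)(=O)=O)cc1` differs from compound 2 by vinyl in place of propyl on a saturated chain carbon bound to an amide-type nitrogen. Among the measured compounds shown here, the only measured step, a number 55 percentage points lower from compound 1 to compound 2 (beyond the scatter), concerns a different change, the addition of the whole chain on the amide-type nitrogen, and so bears on this shortening of the chain only loosely. The step to compound 3 is therefore expected to be no change at the digits printed from compound 2 to compound 3 (within the scatter), within the scatter. The estimate for compound 3 is 40%, with a range from 25% to 60%.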

Compound 3, a percentage reported as activity, at one concentration (the size of the read-out at that concentration, not a potency): 40%
Compound 3: the middle estimate sits on the measured number at the digits printed; low and high end bracket the measured number.
By their numbers in this assay, from the lowest: compounds 2 and 3 (each within the scatter of the next); then compound 1.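

In this assay, vinyl in place of propyl on a saturated chain carbon bound to an amide-type nitrogen gives no change at the digits printed from compound 2 to compound 3 (within the scatter), so butyl and allyl cannot be told apart at this position. The allyl chain shows the same large drop as the butyl chain, with a number 55 percentage points lower from compound 1 to compound 3 (beyond the scatter), so that drop does not depend on the saturated chain end. No measurement here gives a reason for either step. Still open, from the compounds shown here alone, is how a longer chain, or a chain ending in an amine or a carboxylic acid, would read at this position.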